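Fluoro for chloro on the aryl carbinol of compound 3

The source may report more compounds than this note shows. Statements on the series, on what has been measured and on what is new or still open speak of the compounds shown alone.

Measured so far:
compound 1 `Cc1cc(=O)c2c(O)cc(O)c([C@H]3CCN(C)C[C@H]3OC(=O)c3ccco3)c2o1`: 13%
compound 2 `Cc1cc(=O)c2c(O)c(CN(C)CC(=O)O)c(O)c([C@H]3CCN(C)C[C@H]3O)c2o1`: 16%
compound 3 `Cc1oc2c([C@H]3CCN(C)C[C@H]3O)c(O)cc(O)c2c(=O)c1C(O)c1ccc(Cl)cc1`: 15%

In a functional assay on MIA PaCa-2 cells (Homo sapiens) for inhibition, read by MTT assay, with a stated time of 48 h, tested at 10 uM (on this read-out higher numbers stand for more inhibition of growth at the one concentration tested and lower numbers for less inhibition of growth), the three measured compounds sit close together. Compound 3 gives the second highest of the three numbers; its gap to compound 2 and its gap to compound 1 both lie within the scatter of this read-out, so no order among the three can be read from the numbers.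

Compound 4 `Cc1oc2c([C@H]3CCN(C)C[C@H]3O)c(O)cc(O)c2c(=O)c1C(O)c1ccc(F)cc1` differs from compound 3 in one place: fluoro in place of chloro on an aromatic carbon. Within the data shown here, no measured pair shows this change, and nothing among the three compounds points to a move in either direction. The step from compound 3 to compound 4 is expected to be a number 1 percentage points lower from compound 3 to compound 4 (within the scatter), which is no step beyond the scatter. Compound 4 is therefore estimated at 14%, with a range from 4% to 26%.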

Compound 4, percent growth inhibition at one concentration: 17%
Compound 4: the middle estimate sits 3 percentage points below what was measured; low and high end bracket the measured number.
By their numbers in this assay, from the lowest: compounds 1, 3, 2 and 4 (each within the scatter of the next).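

In this assay the change from 4-chlorophenyl to 4-fluorophenyl reads a number 2 percentage points higher from compound 3 to compound 4 (within the scatter) and gives the series its first comparison of compounds differing in one place. On this aromatic carbon, the two halogens do not separate compound 3 from compound 4 on this read-out. No measurement at hand offers an explanation for this result. Still open, on these data alone, is whether an amine, a carboxylic acid or a longer chain on this same carbon would give a number beyond the scatter. Also open, as far as these compounds go, is how the unsubstituted phenyl compares with these two halogenated compounds.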